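This account rests on a few compounds, and the source may have more. Where it says the series, first, only, none or still open, it means among the compounds named here.

Working notes on the series. Going by the values given here, in a functional assay on A549 cells (Homo sapiens) for inhibition, read by sulforhodamine B assay, with a stated time of 74 h (on this read-out lower numbers stand for stronger inhibition and higher numbers for weaker inhibition), compound 1 `Cc1ccc(S(=O)(=O)N2C(=O)COC23C=CC(=O)C=C3)cc1` gives 110 nM, the highest of the three numbers so far, against compound 2 `O=C1C=CC2(C=C1)OCC(=O)N2S(=O)(=O)c1ccc(N2CCCC2=O)cc1` at 5 nM and compound 3 `O=C1C=CC2(C=C1)OCC(=O)N2S(=O)(=O)c1ccc(OC(F)(F)F)cc1` at 40 nM. Compound 4 `O=C1C=CC2(C=C1)OCC(=O)N2S(=O)(=O)c1cccs1` is still unmeasured. Relative to compound 1 it carries thiophen-2-yl in place of 4-methylphenyl on a sulfonyl sulfur.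

Among the compounds with values here, two measured steps bear on this change, both only indirectly. With 2-oxopyrrolidin-1-yl in place of methyl on an aromatic carbon, the large step is a 22-fold lower number from compound 1 to compound 2 (1.34 log units; beyond the scatter). With trifluoromethoxy in the same place, the modest step is a 2.8-fold lower number from compound 1 to compound 3 (0.44 log units; beyond the scatter). Neither step replaces the aromatic ring itself, and neither group is present in compound 4. Both steps lower the number, so a small move in that direction is the working expectation in this assay, possibly no move beyond the scatter. The expected step is a 1.5-fold lower number from compound 1 to compound 4 (0.17 log units; within the scatter). For compound 4 the estimated value is 75 nM, with an expected range of 25 nM to 220 nM.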

Compound 4, half-maximal inhibitory concentration: > 10000 nM
Compound 4 was reported as a limit; the forecaster's own chance of this, stated with the estimate: 3%; at least 130-fold (2.12 log units) between middle value and limit.
By their numbers in this assay, from the lowest: compound 2; then compound 3; then compound 1. At a limit, above all of these: compound 4.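

In this assay, compound 4 is reported only as a limit, not as a number: the limit of > 10000 nM in this assay, at which 1 of the 4 values shown sits. The earlier steps shown here from compound 1 kept the six-membered aromatic ring, changed only the group on an aromatic carbon, and both lowered the number. Replacing 4-methylphenyl itself with thiophen-2-yl on the sulfonyl sulfur goes the other way, with an at least 90-fold higher number from compound 1 to compound 4 (1.95 log units; beyond the scatter), so the identity of the ring at this position can matter more than any substituent change seen so far.

This single change swaps the ring and also removes the methyl group, and the compounds shown do not separate these two differences. A plain phenyl, a methyl-bearing thiophene or a pyridine ring on the sulfonyl sulfur would bear on that question.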